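Replacing 3,4-dimethoxyphenyl with 3-bromophenyl on the carbonyl

A few compounds are considered here, and "the series" means these few. Any claim that something is new, unique, unknown or untested is made for them only; others in the source may bear on it.

Values measured in a functional assay on HepG2 cells (Homo sapiens) for inhibition, read by MTT assay, with a stated time of 24 h; on this read-out lower numbers stand for stronger inhibition of growth and higher numbers for weaker inhibition of growth:
- Compound 1 `Cn1cc(-c2nc3ccccc3n2C(=O)c2ccccc2)c2cc(Br)ccc21`: 48100 nM
- Compound 2 `COc1ccc(C(=O)n2c(-c3cn(C)c4ccc(Br)cc34)nc3ccccc32)cc1`: 18900 nM
- Compound 3 `COc1ccc(C(=O)n2c(-c3cn(C)c4ccc(Br)cc34)nc3ccccc32)cc1OC`: 9700 nM

Compound 3 stands at the low end of these numbers, but not alone. Adding the second methoxy gives a 1.9-fold lower number from compound 2 to compound 3 (0.29 log units; within the scatter). The first methoxy gives a 2.5-fold lower number from compound 1 to compound 2 (0.41 log units; beyond the scatter), and the complete 3,4-dimethoxyphenyl gives a 5.0-fold lower number from compound 1 to compound 3 (0.70 log units; beyond the scatter).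

The unmeasured compound 4 `Cn1cc(-c2nc3ccccc3n2C(=O)c2cccc(Br)c2)c2cc(Br)ccc21` carries this change: 3-bromophenyl in place of 3,4-dimethoxyphenyl on a carbonyl carbon. Both methoxy groups leave, and the measured steps that added them all ran towards lower numbers. Taken alone, this points back towards compound 1 at 48100 nM. However, no measured step shows what the bromine on the 3-bromophenyl does, so a full return is not assumed.

A modest rise in this assay is therefore expected, smaller than the full span of a 5.0-fold lower number from compound 1 to compound 3 (0.70 log units; beyond the scatter). The expected step is a 2.3-fold higher number from compound 3 to compound 4 (0.36 log units; beyond the scatter). For compound 4 the estimated value is 22000 nM, with an expected range of 8000 nM to 55000 nM.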

Compound 4, concentration for 50% growth inhibition: 67300 nM
Estimate against measurement, compound 4: 3.1-fold (0.49 log units) below; the whole stated range lies below it.
By their numbers in this assay, from the lowest: compounds 3 and 2 (each within the scatter of the next); then compounds 1 and 4 (each within the scatter of the next).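

In this assay the change to 3-bromophenyl on the carbonyl carbon gives a 6.9-fold higher number from compound 3 to compound 4 (0.84 log units; beyond the scatter) and, set against 4-methoxyphenyl, gives a 3.6-fold higher number from compound 2 to compound 4 (0.55 log units; beyond the scatter) on the same carbonyl carbon, so at this position a bromine does not do what the methoxy groups did. Bromo in place of hydrogen on the plain phenyl gives a 1.4-fold higher number from compound 1 to compound 4 (0.15 log units; within the scatter) and so leaves the two compounds within the scatter of each other, which makes the lower numbers of the series look tied to methoxy rather than to any added group. Nothing measured here explains this difference between the groups.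

Only one bromo compound is shown, so it stays open whether bromine behaves the same way elsewhere on this phenyl ring. An amine, a carboxylic acid or a fluoro group on that ring could show whether anything other than methoxy lowers the number.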